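A few compounds are considered here, and "the series" means these few. Any claim that something is new, unique, unknown or untested is made for them only; others in the source may bear on it.

Compound 1 `C/C(C(=O)NC1CC1)=C(\C)c1ccc(Br)cc1` gives 300 mg/kg in a toxicity assay on the whole organism (strain Icem-CET (SPF Caw)) for cytotoxicity, with Mus musculus as the target; on this read-out lower numbers stand for an effect already at smaller amounts and higher numbers for an effect only at larger amounts of compound.
Compound 2 `C=CCNC(=O)/C(C)=C(/C)c1ccc(Br)cc1` gives 400 mg/kg.
Compound 3 `C=CCNC(=O)/C(C)=C(\C)c1ccc(Br)cc1` gives 120 mg/kg.

Compound 2 holds the highest number of the three. Compound 1 lies within the scatter of it, a 1.3-fold higher number from compound 1 to compound 2 (0.12 log units; within the scatter), while compound 3 sits beyond it, a 3.3-fold lower number from compound 2 to compound 3 (0.52 log units; beyond the scatter), a step that rests on (the fact that compounds 2 and 3 differ only in the configuration as drawn). Compound 4 `C=CCNC(=O)/C(C)=C(/C)c1ccc(C)cc1` is not yet measured. Its change from compound 2 is methyl in place of bromo on an aromatic carbon. Neither measured step touches the aromatic ring: the allyl-for-cyclopropyl exchange on the amide nitrogen stayed within the scatter, and the configurational step left the ring substituent unchanged. For the measured compounds named here, no measured step bears directly on this change, and a step within the scatter is expected, no change at the digits printed from compound 2 to compound 4 (within the scatter). Compound 4 is estimated at 400 mg/kg, with a range of 180 mg/kg to 900 mg/kg in this assay.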

Compound 4, dose for half-maximal effect: 280 mg/kg
Compound 4: the middle estimate sits 1.4-fold (0.15 log units) above what was measured; low and high end bracket the measured number.
By their numbers in this assay, from the lowest: compound 3; then compounds 4, 1 and 2 (each within the scatter of the next).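

For the compounds shown here, on the six-membered aromatic ring, para to a large group, methyl in place of bromo gives the first reading for this position in this assay: a 1.4-fold lower number from compound 2 to compound 4 (0.15 log units; within the scatter). With the allyl amide and the double bond as drawn in compound 2, the bromo is thus exchanged for methyl without a step beyond the scatter. No information at hand bears on this step.

Open, from the compounds shown here alone, is whether the same exchange stays this small with the double bond as drawn in compound 3. Also open, going by these compounds, is the reading at this position for an amine or a carboxylic acid.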